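The compounds below may be only part of what the source reports. "The series", "measured", "known", "first", "only" and "open" are said of these compounds alone.

In an assay on SK-OV-3 cells for inhibition of eIF-2-alpha kinase GCN2 (Homo sapiens) (on this read-out higher numbers stand for weaker inhibition and lower numbers for stronger inhibition), the three measured compounds stand as follows:
- compound 1, `COCCNC(=O)[C@H]1CC[C@@H](Nc2ncc3c(Br)nn(-c4ccc5ncccc5c4)c3n2)C1`, gives 156 nM
- compound 2, `COCCNC(=O)[C@H]1CC[C@H](Nc2ncc3c(Br)nn(-c4ccc5ncccc5c4)c3n2)C1`, gives 183 nM
- compound 3, `COCCNC(=O)[C@@H]1CC[C@@H](Nc2ncc3c(Br)nn(-c4ccc5ncccc5c4)c3n2)C1`, gives 20 nM

Compound 3 holds the lowest number of the three. The steps between the measured compounds all concern configuration alone: a 1.2-fold higher number from compound 1 to compound 2 (0.07 log units; within the scatter), a 7.8-fold lower number from compound 1 to compound 3 (0.89 log units; beyond the scatter), and a 9.2-fold lower number from compound 2 to compound 3 (0.96 log units; beyond the scatter). The gap between compound 1 and compound 2 stays within the scatter, so no order is claimed between them; compound 3 lies beyond the scatter from both, as the fact that compounds 1 and 3 differ only in the configuration as drawn and the fact that compounds 2 and 3 differ only in the configuration as drawn show.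

Compound 4, `COCCC(=O)N[C@@H]1CC[C@@H](Nc2ncc3c(Br)nn(-c4ccc5ncccc5c4)c3n2)C1`, keeps the configuration of compound 3 and differs from it in one place: ((2-methoxyethyl)carbonyl)amino in place of (2-methoxyethyl)carbamoyl on a saturated ring carbon. For the measured compounds named here, none of the measured steps bears on a change of this kind, since each of them is a change of configuration only and the connection of the side chain is the same in compounds 1, 2 and 3. The direction and size of the step in this assay therefore cannot be read from the measured compounds, and the expectation rests on the change being a rearrangement of the same atoms rather than an addition or loss. Compound 4 is expected to come out near 45 nM, with a range from 12 nM to 180 nM, which would mean an expected step of a 2.3-fold higher number from compound 3 to compound 4 (0.35 log units; beyond the scatter).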

Compound 4, half-maximal inhibitory concentration: 159 nM
Compound 4: the middle estimate sits 3.5-fold (0.55 log units) below what was measured, and the stated range covers the measured number.
By their numbers in this assay, from the lowest: compound 3; then compounds 1, 4 and 2 (each within the scatter of the next).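

In this assay, for the compounds shown here, ((2-methoxyethyl)carbonyl)amino in place of (2-methoxyethyl)carbamoyl on the saturated ring carbon gives an 8.0-fold higher number from compound 3 to compound 4 (0.90 log units; beyond the scatter), so the number at this position depends on how the same atoms are joined, and not only on the configuration that separated the earlier compounds. The leaving and entering groups match in every count computed for them, so this step arises with heavy atoms, hydrogen-bond donors and hydrogen-bond acceptors unchanged in number, and what differs is the direction of the connection to the ring. What is known about these compounds concerns configuration alone and offers no explanation for a change in that connection.

The compounds shown leave open whether the side chain needs its amide link at all, which an amine or a carboxylic acid at the same ring carbon would address, and whether a longer chain would alter the picture for either connection. They also leave open how the other configurations of the ((2-methoxyethyl)carbonyl)amino compound would stand, and so whether the preference seen among compounds 1, 2 and 3 carries over to the reversed connection.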